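This account rests on a few compounds, and the source may have more. Where it says the series, first, only, none or still open, it means among the compounds named here.

Compound 1 `c1cc(CNC2CCCCC2)ccc1CNC1CCCCC1`: > 10000 nM in an assay on CHO cells for displacement of a labelled ligand from C-X-C chemokine receptor type 4 (Homo sapiens), with a stated time of 40 min; on this read-out higher numbers stand for weaker inhibition and lower numbers for stronger inhibition; this value is a limit of the assay, not a number.
Compound 2 `c1cc(CNCCCNC2CCCCC2)cc(CNCCCNC2CCCCC2)c1`: 156 nM
Compound 3 `Nc1cc(CNCCCNC2CCCCC2)ccc1CNCCCNC1CCCCC1`: 68.9 nM

Compound 2 holds the higher of the two numbers given in this assay; compound 3 sits lower, beyond the usual scatter. Compound 1 gives only a limit (the limit of > 10000 nM in this assay, at which 1 of the 3 values shown sits). No pair of these compounds differs in a single place, so no measured step is available.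

Compound 4 `CN(C)c1cc(CNCCCNC2CCCCC2)cc(CNCCCNC2CCCCC2)c1` is not yet measured. Relative to compound 2 it carries dimethylamino in place of hydrogen on an aromatic carbon. A nitrogen substituent on the shared core is also borne by compound 3, and compound 3 gives 68.9 nM, a lower number than compound 2. A step of similar size in the same direction, or none beyond the scatter, is expected from compound 2 to compound 4 a 1.6-fold lower number from compound 2 to compound 4 (0.19 log units; within the scatter). Compound 4 is estimated at 100 nM, between 45 nM and 250 nM.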

Compound 4, half-maximal inhibitory concentration: 119 nM
Estimate against measurement, compound 4: 1.2-fold (0.08 log units) below, and the stated range covers the measured number.
By their numbers in this assay, from the lowest: compounds 3, 4 and 2 (each within the scatter of the next, the first and the last beyond it). At a limit, above all of these: compound 1.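

In this assay, dimethylamino in place of hydrogen on an aromatic carbon, meta to two large groups, gives a 1.3-fold lower number from compound 2 to compound 4 (0.12 log units; within the scatter). Among the compounds shown here, this is the first single-place step, and it shows that this position accepts these added heavy atoms with no change beyond the scatter. Nothing shown bears on a cause for this step.

Still open, from the compounds shown here alone, is whether a carboxylic acid or a methoxy group at this place would also stay within the scatter. Also open, going by these compounds, is how a longer chain in the two side arms would affect the number.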